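Thiocyanate series: aryl substituent and cytotoxicity

The compounds below may be only part of what the source reports. "The series", "measured", "known", "first", "only" and "open" are said of these compounds alone.

Measured so far:
compound 1 `Clc1ccc(Cc2nn3cc(-c4ccccc4)nc3s2)cc1`: > 250000 nM
compound 2 `N#CSc1c(-c2ccc(Cl)cc2)nc2sc(Cc3ccc(Cl)cc3)nn12`: 49000 nM
compound 3 `COc1ccc(-c2nc3sc(Cc4ccc(Cl)cc4)nn3c2SC#N)cc1`: 16000 nM

In a functional assay on L1210 cells (Mus musculus) for cytotoxicity, with a stated time of 48 h (a lower number here means a stronger inhibitor, a higher number a weaker inhibitor), compound 1 gives only a limit, (the limit of > 250000 nM in this assay, at which 1 of the 3 values shown sits), and no number. Among the two numbers recorded, compound 3 holds the lowest; its nearest neighbour is compound 2, and the step of a 3.1-fold lower number from compound 2 to compound 3 (0.49 log units; beyond the scatter) lies beyond the scatter. Compound 4 `N#CSc1c(-c2ccccc2)nc2sc(Cc3ccc(Cl)cc3)nn12` is not yet measured. It differs from compound 3 by hydrogen in place of methoxy on an aromatic carbon. Going by the values given here, no measured pair shows this exact change; the one step that bears on the same position, a 3.1-fold lower number from compound 2 to compound 3 (0.49 log units; beyond the scatter), was modest, so a step of similar size, in either direction, is the reasonable expectation. Compound 1 and compound 4 differ only by the thiocyanate, and compound 1 sits at a limit, which gives no number to lean on. Compound 4 is expected to land at 30000 nM, within 10000 nM to 100000 nM, the expected step being a 1.9-fold higher number from compound 3 to compound 4 (0.27 log units; within the scatter).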

Compound 4, half-maximal inhibitory concentration: 24000 nM
Compound 4: middle estimate off by 1.3-fold (0.10 log units), on the high side; the range from low to high includes it.
By their numbers in this assay, from the lowest: compounds 3 and 4 (each within the scatter of the next); then compound 2. At a limit, above all of these: compound 1.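

In this assay, this position now has a reading without a substituent: a 1.5-fold higher number from compound 3 to compound 4 (0.18 log units; within the scatter), so hydrogen and methoxy cannot be told apart here. Chloro does stand apart, with a 2.0-fold lower number from compound 2 to compound 4 (0.31 log units; beyond the scatter), so among these three groups only compound 2 separates from the others, and the position shows a small range so far. The thiocyanate carries the largest change in the series, an at least 10-fold lower number from compound 1 to compound 4 (1.01 log units; beyond the scatter), though only as a bound, as compound 1 is a limit and not a number: the limit of > 250000 nM in this assay, at which 1 of the 4 values shown sits.

Still open, from the compounds shown here alone, is whether an amine or a carboxylic acid at the same place on the aromatic ring would move the number beyond the scatter of hydrogen and methoxy. Also open, going by these compounds, is whether a nitrile or a longer chain could stand in for the thiocyanate.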